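Removing a Chloro Group: Expected Effect on Cytotoxicity

The compounds below may be only part of what the source reports. "The series", "measured", "known", "first", "only" and "open" are said of these compounds alone.

Compound 1 `Cc1nnc(SCc2cc(=O)c3cc(Cl)ccc3o2)s1`: > 25000 nM
Compound 2 `Cc1cc(C)nc(SCc2cc(=O)c3cc(Cl)ccc3o2)n1`: > 25000 nM

Both compounds were tested in a functional assay on SW480 cells (Homo sapiens) for cytotoxicity, read by MTT assay, with a stated time of 72 h; on this read-out lower numbers stand for stronger inhibition and higher numbers for weaker inhibition. Compound 1 gives only a limit of the assay there, > 25000 nM. Compound 2 likewise gives only a limit, > 25000 nM. Compound 2 thus stands at the limit of > 25000 nM in this assay, at which 2 of the 2 values shown sit, with no real number to compare against. Compound 3 `Cc1cc(C)nc(SCc2cc(=O)c3ccccc3o2)n1` differs from compound 2 in a single place: hydrogen in place of chloro on an aromatic carbon. For the measured compounds named here, no measured step exists to guide the expectation, so the step that the limit leaves unreadable from compound 2 to compound 3 is expected to stay within the usual scatter, with no set direction. Compound 3 is therefore estimated at 30000 nM, in a range from 12000 nM to 100000 nM, most likely again reported only as a limit.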

Compound 3, half-maximal inhibitory concentration: > 25000 nM
Compound 3: no number, only a limit; the forecaster's own chance of this, stated with the estimate: 80%; the middle value is on the limit's open side.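

No step can be read from compound 2 to compound 3, as both give only a limit: the limit of > 25000 nM in this assay, at which 3 of the 3 values shown sit. These compounds leave open whether chloro or hydrogen at this place changes cytotoxicity at all.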